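A few compounds are considered here, and "the series" means these few. Any claim that something is new, unique, unknown or untested is made for them only; others in the source may bear on it.

In a functional assay on KB cells (Homo sapiens) for antiproliferative activity, read by sulforhodamine B assay, with a stated time of 3 days (on this read-out higher numbers stand for an effect only at larger amounts of compound and lower numbers for an effect already at smaller amounts), three compounds on a shared core differ in one aromatic substituent: compound 1 (`CCC1=C(O)c2c(oc(-c3ccc(C(C)C)cc3)cc2=O)C(CC)(CC)C1=O`) gives 8.13 uM, compound 2 (`CCC1=C(O)c2c(oc(-c3ccc(C(F)(F)F)cc3)cc2=O)C(CC)(CC)C1=O`) gives 35.7 uM, and compound 3 (`CCC1=C(O)c2c(oc(-c3ccc(O)cc3)cc2=O)C(CC)(CC)C1=O`) gives 20.6 uM. Compound 3 stands close to compound 2, with a 1.7-fold lower number from compound 2 to compound 3 (0.24 log units; within the scatter), and apart from compound 1, with a 2.5-fold higher number from compound 1 to compound 3 (0.40 log units; beyond the scatter). Compound 4 (`CCC1=C(O)c2c(oc(-c3ccc(OC(F)(F)F)cc3)cc2=O)C(CC)(CC)C1=O`) carries trifluoromethyl in place of hydrogen on an oxygen on an aromatic ring, trifluoromethyl in place of hydrogen on an oxygen on an aromatic ring, so hydroxy becomes trifluoromethoxy. The largest measured swap at this aromatic carbon is a 4.4-fold higher number from compound 1 to compound 2 (0.64 log units; beyond the scatter), a modest step, so no step beyond the scatter is expected in this assay. The expected step is a 1.1-fold lower number from compound 3 to compound 4 (0.06 log units; within the scatter). For compound 4 the estimated value is 18 uM, with an expected range from 7 uM to 45 uM.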

Compound 4, concentration for half-maximal effect: 36.5 uM
Estimate against measurement, compound 4: 2.0-fold (0.31 log units) below; the measured number falls inside the stated range.
By their numbers in this assay, from the lowest: compound 1; then compounds 3, 2 and 4 (each within the scatter of the next).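

In this assay, putting trifluoromethyl on the oxygen of the hydroxy group gives a 1.8-fold higher number from compound 3 to compound 4 (0.25 log units; within the scatter), and trifluoromethoxy in place of trifluoromethyl on the aromatic carbon gives a 1.0-fold higher number from compound 2 to compound 4 (0.01 log units; within the scatter), so compound 2, compound 3 and compound 4 cannot be told apart. Only isopropyl stands apart, with a 4.5-fold higher number from compound 1 to compound 4 (0.65 log units; beyond the scatter), the same size of gap that separated it from trifluoromethyl. Nothing measured on these compounds accounts for this.

On these data alone, whether a longer chain, such as butyl, would stay with isopropyl remains open, as does where an amine or a carboxylic acid would fall.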